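The source may hold more compounds than are shown below. What is called first, only, known or untested is meant among the compounds shown, and "the series" means these compounds.

Measured so far in a physicochemical assay for metabolic stability, read by spectrophotometry, in phosphate buffer, at 25 degrees C, at pH 7.3 (a higher number here means that the compound lasts longer, a lower number that the compound disappears faster), on the series:

Compound 1 `Cc1cccc(C(=O)n2cc(C#N)c3cccnc32)c1` gives 1.9 h
Compound 2 `Cc1cccc(C(=O)n2cc(C(=O)Nc3ccccc3)c3cccnc32)c1` gives 3.4 h

The step of a 1.8-fold higher number from compound 1 to compound 2 (0.25 log units; within the scatter) is the only one measured, so compound 2 stands within the scatter of compound 1. Compound 3 `Cc1cccc(C(=O)n2cc([N+](=O)[O-])c3cccnc32)c1` carries nitro in place of phenylcarbamoyl on an aromatic carbon. Within the data shown here, the measured step lies at that same aromatic carbon and stayed within the scatter, but no nitro compound has been measured. Like the cyano of compound 1 (1.9 h), nitro brings no ring, so a value closer to compound 1 than to compound 2 is expected in this assay. The estimated change (a 1.9-fold lower number from compound 2 to compound 3 (0.28 log units; within the scatter)) leans to a lower number, and no step beyond the scatter is expected. For compound 3 the expected half-life is 1.8 h within an estimated range from 0.7 h to 3.8 h for now.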

Compound 3, half-life: 0.4 h
The estimate for compound 3 lay 4.5-fold (0.65 log units) above the measured number; the whole stated range lies above it.
By their numbers in this assay, from the lowest: compound 3; then compounds 1 and 2 (each within the scatter of the next).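

Among these compounds, at this aromatic carbon, two bonds from the ring nitrogen, the choice of group can move the half-life in this assay beyond the scatter: nitro in place of phenylcarbamoyl gives an 8.5-fold lower number from compound 2 to compound 3 (0.93 log units; beyond the scatter) and nitro in place of cyano gives a 4.8-fold lower number from compound 1 to compound 3 (0.68 log units; beyond the scatter), whereas the one earlier step stayed within it. Having no ring in the group therefore does not place a compound with compound 1, since cyano and nitro, both without a ring, lie apart. Nothing at hand accounts for the lower number of compound 3.

Going by these compounds, whether that number is particular to nitro stays open; an amine, a carboxylic acid or a methyl ester on the same carbon would bear on this. Also open, on these data alone, is whether the step holds when the (3-methylphenyl)carbonyl group is replaced by another acyl group.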